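A few compounds are considered here, and "the series" means these few. Any claim that something is new, unique, unknown or untested is made for them only; others in the source may bear on it.

In a physicochemical assay for solubility, in phosphate buffer, with a stated time of 24 h, at pH 7.4 (a lower number here means a less soluble compound, a higher number a more soluble compound), compound 1 (`COc1ccc(-c2ccc(OCc3cc(C(=O)NS(=O)(=O)c4ccccc4)oc3C)cc2)c(C)c1`) gives 20 ug/mL. Compound 2 (`Cc1oc(C(=O)NS(=O)(=O)c2ccccc2)cc1COc1ccc(-c2ccc(OC(F)F)cc2)cc1`) gives < 0.6 ug/mL, which is a limit of the assay and not a number. Going by the values given here, the one measured step is an at least 33-fold lower number from compound 1 to compound 2 (1.52 log units; beyond the scatter), a large one. Compound 2 therefore offers no exact starting point, only (the limit of < 0.6 ug/mL in this assay, at which 1 of the 2 values shown sits). Compound 3 (`Cc1noc(C)c1S(=O)(=O)NC(=O)c1cc(COc2ccc(-c3ccc(OC(F)F)cc3)cc2)c(C)o1`) differs from compound 2 by 3,5-dimethyl-1,2-oxazol-4-yl in place of phenyl on a sulfonyl sulfur, with 3,5-dimethyl-1,2-oxazol-4-yl in place of phenyl on a sulfonyl sulfur. The measured step lay on an aromatic carbon rather than on this sulfonyl sulfur, so it bears only indirectly, showing that one exchange can move this assay strongly. A modest upward move is expected here, not one on the scale of that step. The expected step is an at least 2.0-fold higher number from compound 2 to compound 3 (0.30 log units; that floor lies within the scatter). For compound 3 the estimated value is 1.2 ug/mL, with an expected range from 0.3 ug/mL to 6 ug/mL.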

Compound 3, solubility: < 0.6 ug/mL
Compound 3: a limit, no number; the forecaster's own chance of this, stated with the estimate: 45%; middle value at least 2.0-fold (0.30 log units) from the limit.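

In this assay, compound 2 and compound 3 both give a limit and not a number, so no step can be read between them: the limit of < 0.6 ug/mL in this assay, at which 2 of the 3 values shown sit.

The compounds shown leave open how far, and in which direction, 3,5-dimethyl-1,2-oxazol-4-yl in place of phenyl on a sulfonyl sulfur moves solubility.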